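The source may report more compounds than this note shows. Statements on the series, on what has been measured and on what is new or still open speak of the compounds shown alone.

Compound 1, `Cc1cc(C(=O)O)c(C)[nH]1`, is the shared core with nothing attached beyond it. In an assay on cells for inhibition of Palmitoleoyl-protein carboxylesterase NOTUM variant C330S (Homo sapiens), read by fluorescence, with a stated time of 40 min (on this read-out lower numbers stand for stronger inhibition and higher numbers for weaker inhibition), compound 1 gives only a limit of the assay, > 100000 nM. Compound 2, `Cc1cc(C(=O)O)c(C)n1-c1cccc(C#N)c1F`, adds a six-membered aromatic ring of carbon only bearing fluoro and cyano; in this assay compound 2 gives 630 nM, the lowest of the two numbers shown, while compound 3, `Cc1cc(C(=O)O)c(C)n1-c1cccc(C#N)c1`, gives 3100 nM. The step of a 4.9-fold higher number from compound 2 to compound 3 (0.69 log units; beyond the scatter) shows that a change on that aromatic ring moves the number. Compound 4, `Cc1cc(C(=O)O)c(C)n1-c1cccc(C2CC2)c1F`, differs from compound 2 by cyclopropyl in place of cyano on an aromatic carbon. Going by the values given here, no measured step touches the cyano group itself, so the fluoro step is the only guide to how much such a change can matter. The expected step is a 1.6-fold higher number from compound 2 to compound 4 (0.20 log units; within the scatter). Compound 4 is thus estimated at 1000 nM, with a range from 200 nM to 5000 nM.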

Compound 4, half-maximal inhibitory concentration: 200 nM
Compound 4: the middle estimate sits 5.0-fold (0.70 log units) above what was measured, within the range that was stated.
By their numbers in this assay, from the lowest: compound 4; then compound 2; then compound 3. At a limit, above all of these: compound 1.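

In this assay, the step of a 3.2-fold lower number from compound 2 to compound 4 (0.50 log units; beyond the scatter) shows that the cyano group is not needed at this position on the aromatic ring. Cyclopropyl, which brings a three-membered ring and no hydrogen-bond acceptor, gives the lower number in its place. Earlier, only the fluoro step had shown a change on this ring moving the number, so this is the first evidence about the second group. Going by these compounds, whether an amine, a methyl group or a larger ring such as cyclohexyl would serve here stays open. Nothing measured here explains why cyclopropyl gives the lower number.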